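Swapping the cyclopropyl aryl group in a receptor agonist series

The source may report more compounds than this note shows. Statements on the series, on what has been measured and on what is new or still open speak of the compounds shown alone.

Measured so far:
compound 1, `O=C([C@@H]1C[C@H]1c1ccccc1)N(CC1CCCNC1)c1ccc(-c2ccccc2)cc1`, 10 nM
compound 2, `CC[C@H](C)[C@H](N)CN(C(=O)[C@@H]1C[C@H]1c1ccc(OC)cc1)c1ccc(-c2ccccc2)cc1`, > 25000 nM

Of the compounds shown here, two have been tested in a functional assay for agonist activity at G protein-coupled receptor 88 (Homo sapiens), read by HTRF and cAMP accumulation; on this read-out lower numbers stand for an effect already at smaller amounts and higher numbers for an effect only at larger amounts of compound. Compound 1, with the structure `O=C([C@@H]1C[C@H]1c1ccccc1)N(CC1CCCNC1)c1ccc(-c2ccccc2)cc1`, gives 10 nM in this assay. Compound 2, with the structure `CC[C@H](C)[C@H](N)CN(C(=O)[C@@H]1C[C@H]1c1ccc(OC)cc1)c1ccc(-c2ccccc2)cc1`, reaches only a limit of the assay, > 25000 nM, so no number is known for it; this is the limit of > 25000 nM in this assay, at which 1 of the 2 values shown sits. The two structures differ in more than one place, so their values can only be read side by side, not as a single step.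

Compound 3, `CC[C@H](C)[C@H](N)CN(C(=O)[C@@H]1C[C@H]1c1ncc(C)s1)c1ccc(-c2ccccc2)cc1`, has not yet been measured. It differs from compound 2 by one change, (5-methyl-1,3-thiazol-2-yl in place of 4-methoxyphenyl on a saturated ring carbon). Within the data shown here, no measured pair shows what this kind of change does in this assay. With compound 2 at a limit, any step from compound 2 to compound 3 can only be read as a move from that limit, and the expected step of an at least 1.6-fold lower number from compound 2 to compound 3 (0.22 log units; that floor lies within the scatter) is a modest gain at best, quite possibly none beyond the scatter. The expected value for compound 3 in this assay is 15000 nM, in the range from 2000 nM to 25000 nM.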

Compound 3, half-maximal effective concentration: 1300 nM
The estimate for compound 3 lay 12-fold (1.06 log units) above the measured number; the measured number lies below the stated range.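

In this assay, 5-methyl-1,3-thiazol-2-yl in place of 4-methoxyphenyl gives an at least 19-fold lower number from compound 2 to compound 3 (1.28 log units; beyond the scatter). Among these compounds, this is the first single change that can be read in this set, and it shows that the group on this saturated ring carbon of the three-membered ring can by itself take a compound from no measurable value to a measured one, with everything else in the structure unchanged. The true size of the step remains unknown, and the figure is only a floor, as compound 2 stands at a limit and has no number of its own: the limit of > 25000 nM in this assay, at which 1 of the 3 values shown sits.

The compounds shown do not reveal whether the gain comes from the five-membered ring with its two hetero atoms or from the methyl group on it, a question that the unsubstituted 1,3-thiazol-2-yl or a pyridin-2-yl group on the same carbon would help to settle. On these data alone, compound 1 differs from compound 3 in more than one place, so it also remains open how much of what separates their values belongs to this ring carbon and how much to the amine-bearing chain on the amide nitrogen.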